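Trimming the amide ethyl group in a two-compound series

This account rests on a few compounds, and the source may have more. Where it says the series, first, only, none or still open, it means among the compounds named here.

Compound 1 `CCN(C(=O)CC(CC(=O)NCCN1CCCCC1)c1ccc(Cl)cc1)C1Cc2ccccc2C1`: 16500 nM
Compound 2 `CCN(C(=O)CC(CC(=O)NCCN1CCCC1)c1ccc(Cl)cc1)C1Cc2ccccc2C1`: 20400 nM
Compound 3 `CN(C(=O)CC(CC(=O)NCCN1CCCC1)c1ccc(Cl)cc1)C1Cc2ccccc2C1`: not yet measured

In a functional assay on MCF7 cells (Homo sapiens) for inhibition (on this read-out higher numbers stand for weaker inhibition and lower numbers for stronger inhibition), compound 2 gives 20400 nM, which lies within the scatter of compound 1. Compound 3 carries one change: hydrogen in place of methyl on a saturated chain carbon bound to an amide-type nitrogen. Within the data shown here, the only measured step, a 1.2-fold higher number from compound 1 to compound 2 (0.09 log units; within the scatter), concerns pyrrolidin-1-yl in place of piperidin-1-yl, not this place, so it offers only weak guidance. No step beyond the scatter is expected. The expected step is a 1.1-fold higher number from compound 2 to compound 3 (0.03 log units; within the scatter). Compound 3 is estimated at 22000 nM, with a range of 11000 nM to 42000 nM.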

Compound 3, half-maximal inhibitory concentration: 76700 nM
Compound 3: the middle estimate sits 3.5-fold (0.54 log units) below what was measured; the whole stated range lies below it.
By their numbers in this assay, from the lowest: compounds 1 and 2 (each within the scatter of the next); then compound 3.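

In this assay, replacing methyl with hydrogen on a saturated chain carbon bound to an amide-type nitrogen, which cuts ethyl to methyl, gives a 3.8-fold higher number from compound 2 to compound 3 (0.58 log units; beyond the scatter) and so weakens inhibition beyond the scatter. This position therefore responds to the loss of a single carbon, whereas the earlier swap of piperidin-1-yl for pyrrolidin-1-yl stayed within the scatter. No available evidence accounts for this difference. From the compounds shown here alone, whether a longer chain such as propyl would strengthen inhibition remains open, as does whether the same trim would weaken inhibition with piperidin-1-yl in place of pyrrolidin-1-yl.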